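Chloro for methyl in a series seen only at its limit

This account rests on a few compounds, and the source may have more. Where it says the series, first, only, none or still open, it means among the compounds named here.

In an ADME assay on Vero 76 cells (Chlorocebus sabaeus) for cytotoxicity, read by MTT assay, with a stated time of 96 h (on this read-out lower numbers stand for higher toxicity in this test and higher numbers for lower toxicity in this test), compound 1 `Cc1ccc(NCc2cn(-c3ccccc3)nc2-c2ccc(Cl)cc2)cc1` gives > 100000 nM as a limit. Compound 2 `Cc1ccc(NCc2cn(-c3ccccc3)nc2-c2ccc(C)cc2)cc1` gives > 100000 nM as a limit too, so its standing is known no more closely than that. Compound 3 `Cc1ccc(NCc2cn(-c3ccccc3)nc2-c2ccc(Br)cc2)cc1` gives > 100000 nM as a limit as well. Compound 4 `Cc1ccc(-c2nn(-c3ccccc3)cc2CNc2ccc(Cl)cc2)cc1` differs from compound 2 by chloro in place of methyl on an aromatic carbon and so carries (4-chlorophenyl)amino in place of (4-methylphenyl)amino. Exchanges elsewhere on the shared core give a step that the two limits leave unreadable from compound 1 to compound 2 and a step that the two limits leave unreadable from compound 1 to compound 3 and a step that the two limits leave unreadable from compound 2 to compound 3 and so offer no readable size. For the measured compounds named here, with the limit of > 100000 nM in this assay, at which 3 of the 3 values shown sit, as the only guide, no step beyond the scatter is expected in this assay and the estimated change is a number no higher from compound 2 to compound 4 (the limit leaves the size open) at most nominally. Compound 4 is expected at 100000 nM as an estimate, within 50000 nM to 200000 nM and quite probably reported only as a limit.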

Compound 4, half-maximal cytotoxic concentration: > 100000 nM
Compound 4 ended at the assay's limit (the forecaster's own chance of this, stated with the estimate: 85%); the middle value lies on the limit itself.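

For the compounds shown here, compound 2 and compound 4 both sit at a limit in this assay, so no step between them can be read. The compounds shown leave open whether any exchange on the shared core alters this read-out.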